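Removal of the benzylic methyl in the glucagon receptor series

The compounds below may be only part of what the source reports. "The series", "measured", "known", "first", "only" and "open" are said of these compounds alone.

Measured so far:
compound 1 `C[C@H](c1ccc(C(=O)NCCC(=O)O)cc1)N1C(=O)C(c2cccc(C3CC3)c2)=N[C@]12CC[C@@H](C(C)(C)C)CC2`: 1700 nM
compound 2 `CC(C)(C)[C@H]1CC[C@]2(CC1)N=C(c1cccc(C(F)(F)F)c1)C(=O)N2Cc1ccc(C(=O)NCCC(=O)O)cc1`: 10000 nM
compound 3 `C[C@H](c1ccc(C(=O)NCCC(=O)O)cc1)N1C(=O)C(c2cccc(Cl)c2)=N[C@]12CC[C@@H](C(C)(C)C)CC2`: 3300 nM

In an assay on membranes from liver for displacement of a labelled ligand from Glucagon receptor (Mus musculus), read by scintillation counting, with a stated time of 60 min (on this read-out lower numbers stand for stronger inhibition and higher numbers for weaker inhibition), compound 3 gives 3300 nM, the second highest of the three numbers. Its nearest neighbour is compound 1, with a 1.9-fold higher number from compound 1 to compound 3 (0.29 log units; within the scatter), a gap within the scatter. Compound 2 stands furthest from it, beyond the scatter.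

Compound 4 `CC(C)(C)[C@H]1CC[C@]2(CC1)N=C(c1cccc(Cl)c1)C(=O)N2Cc1ccc(C(=O)NCCC(=O)O)cc1` is to be measured in this assay. It differs from compound 3 by hydrogen in place of methyl on a saturated chain carbon bound to an amide-type nitrogen in a ring and an aromatic carbon.

Among the compounds with values here, no measured step covers this change alone. Within the data shown here, compound 2 is the only measured compound carrying hydrogen at that carbon, and it gives 10000 nM in this assay, while compound 1 with methyl there and a different aromatic substituent gives 1700 nM; those two differ in two places, so the comparison is indirect. Among the measured compounds shown here, a step toward a higher number is therefore expected, of the order a 2.4-fold higher number from compound 3 to compound 4 (0.38 log units; beyond the scatter), though the single indirect comparison makes the size uncertain.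

Compound 4 is estimated at 8000 nM, within a range of 2500 nM to 25000 nM.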

Compound 4, half-maximal inhibitory concentration: > 10000 nM
Compound 4: no number, only a limit; the forecaster's own chance of this, stated with the estimate: 25%; at least 1.2-fold (0.09 log units) between middle value and limit.
By their numbers in this assay, from the lowest: compounds 1 and 3 (each within the scatter of the next); then compound 2.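

Compound 4 gives a limit, not a number, in this assay: the limit of > 10000 nM in this assay, at which 1 of the 4 values shown sits. The earlier compounds shown here offered no comparison at this saturated chain carbon that differed in one place only; hydrogen in place of methyl now gives an at least 3.0-fold higher number from compound 3 to compound 4 (0.48 log units; beyond the scatter), a step beyond the scatter that links the methyl group to the lower number in the chloro pair. Chloro in place of trifluoromethyl gives a number no lower from compound 2 to compound 4 (the limit leaves the size open), and this step cannot be read.

As far as these compounds go, the full size of the step at this carbon stays open, as does whether it holds with cyclopropyl on the aromatic carbon. Nothing shown tells how an ethyl or hydroxymethyl group at this carbon would compare with methyl.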